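From 3,5-difluorophenyl to phenyl on an aromatic nitrogen

The source may report more compounds than this note shows. Statements on the series, on what has been measured and on what is new or still open speak of the compounds shown alone.

Measured in an ADME assay on a cell-free system (plasma, Rattus norvegicus) for protein binding, read by LC-MS, using ultracentrifugation, tested at 5 uM; a higher number here means a larger unbound share of the compound, a lower number a smaller unbound share:
- compound 1 `C[C@H](Nc1ncnc(N)c1C#N)c1nc2ccc(F)cc2n1-c1ccc(F)cc1`: 0.1
- compound 2 `C[C@H](Nc1ncnc(N)c1C#N)c1nc2ccc(F)cc2n1-c1cc(F)cc(F)c1`: 0.13

Only these two compounds have been measured, and their values lie within the scatter of each other. Compound 2, at 0.13, therefore cannot be separated from compound 1 in this assay. The next compound, compound 3 `C[C@H](Nc1ncnc(N)c1C#N)c1nc2ccc(F)cc2n1-c1ccccc1`, keeps the shared core and carries phenyl in place of 3,5-difluorophenyl on an aromatic nitrogen.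

Among the compounds with values here, one measured step bears on this change, since it is an exchange at the same aromatic nitrogen: a 1.3-fold higher number from compound 1 to compound 2 (0.11 log units; within the scatter). Within the data shown here, that step is small, but it is the only guide, and no measured compound carries phenyl at this place. The direction of any shift therefore remains poorly defined, and nothing beyond the scatter is expected. The expected change is a 1.1-fold higher number from compound 2 to compound 3 (0.03 log units; within the scatter), a shift that would stay inside the scatter. For compound 3 the estimated value is 0.14, with an expected range from 0.08 to 0.24.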

Compound 3, unbound fraction: 0.09
Compound 3: middle estimate off by 1.6-fold (0.19 log units), on the high side, and the stated range covers the measured number.
By their numbers in this assay, from the lowest: compounds 3, 1 and 2 (each within the scatter of the next).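

In this assay, taking both fluoro groups off the aryl ring gives a 1.4-fold lower number from compound 2 to compound 3 (0.16 log units; within the scatter), and taking off the single fluoro gives a 1.1-fold lower number from compound 1 to compound 3 (0.05 log units; within the scatter), so both steps stay within the scatter. Phenyl, 4-fluorophenyl and 3,5-difluorophenyl on the aromatic nitrogen therefore cannot be told apart by unbound fraction, and within these three compounds the presence, number and placement of fluoro on this ring shows no readable effect. Nothing at hand offers an explanation for the small differences among these three numbers.

All three compounds keep a six-membered aromatic ring of carbon only at this place, so the compounds shown leave open whether a different group there, such as a cyclohexyl ring, a pyridine ring or a phenyl ring bearing a carboxylic acid or an amine, would move the unbound fraction beyond the scatter. They also leave open whether changes elsewhere on the shared core, for instance at the fluoro on the fused ring system or at the nitrile, would shift this read-out more than the exchanges on the aryl ring have.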